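The source may hold more compounds than are shown below. What is called first, only, known or untested is meant among the compounds shown, and "the series" means these compounds.

Measured in an ADME assay on a cell-free system (plasma, Homo sapiens) for metabolic stability, read by HPLC; on this read-out higher numbers stand for a longer-lived compound and lower numbers for a shorter-lived compound:
- compound 1 `CCCC(CCC)C(=O)N(C)/N=N/c1ccc(C(N)=O)cc1`: > 40 h
- compound 2 `CCCC(CCC)C(=O)N(C)/N=N/c1ccc(Cl)cc1`: > 40 h

Compound 2 stands at > 40 h, which is a limit of this assay and not a number. Compound 1 gives > 40 h, also a limit. Both measured compounds therefore sit at the same limit: the limit of > 40 h in this assay, at which 2 of the 2 values shown sit.

Compound 3 `CCCC(CCC)C(=O)N(C)/N=N/c1ccc(Br)cc1` differs from compound 2 as follows: bromo in place of chloro on an aromatic carbon. In words, this is bromo in place of chloro on an aromatic carbon, para to a large group.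

Going by the values given here, the only measured step bearing on this change is a step that the two limits leave unreadable from compound 1 to compound 2, and it gives no readable size. No step beyond the scatter is expected in this assay, and no direction can be assigned. The estimated step is a step that the limit leaves unreadable from compound 2 to compound 3. For compound 3 the expected half-life is 50 h, with an estimated range of 35 h to 90 h, and a report at the limit is likely.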

Compound 3, half-life in the Homo sapiens assay: > 40 h
Compound 3: a limit, no number (the forecaster's own chance of this, stated with the estimate: 85%); the middle value is on the limit's open side.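

In the Homo sapiens assay no new step can be read among compound 1, compound 2 and compound 3: the limit of > 40 h in the Homo sapiens assay, at which 3 of the 3 values shown sit.

In the Homo sapiens assay compound 3 gives > 40 h and this is a limit of the assay, not a number.

The compounds shown leave open how long each one actually lasts in the Homo sapiens assay, and so whether carbamoyl, chloro and bromo differ there at all.

In a physicochemical assay for pharmacokinetics, read by HPLC, in phosphate buffer, at pH 7.4 (a lower number here means that the compound disappears faster, a higher number that the compound lasts longer), compound 2 gives 27.3 h and compound 3 gives 30.4 h as measured values. In the physicochemical assay the step is a 1.1-fold higher number from compound 2 to compound 3 (0.05 log units; within the scatter) and so bromo and chloro cannot be told apart there.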